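The source may hold more compounds than are shown below. What is called first, only, known or untested is meant among the compounds shown, and "the series" means these compounds.

In a functional assay (microsomes, liver) with Rattus norvegicus as the target (on this read-out lower numbers stand for stronger inhibition and higher numbers for weaker inhibition), two compounds sharing one core have been measured so far: compound 1 `Cc1c(C)c2c(c(C)c1N)CC(C)(CSc1ccccc1)O2` gives 270 nM on this read-out, and compound 2 `CCCSCC1(C)Cc2c(C)c(N)c(C)c(C)c2O1` gives 280 nM on the same read-out. Compound 2 therefore stands level with compound 1, within the usual scatter of repeat measurements. Compound 3 `Cc1c(C)c2c(c(C)c1N)CC(C)(CNc1ccccc1)O2` departs from compound 2 in its side chain, with anilino in place of propylsulfanyl on a saturated chain carbon bound to a saturated ring carbon. Going by the values given here, only one measured step bears on this change. The step of a 1.0-fold higher number from compound 1 to compound 2 (0.02 log units; within the scatter) put propyl in place of phenyl on a sulfur and stayed within the scatter, so an aromatic ring and a propyl chain on sulfur read alike here. Among the compounds with values here, no measured compound shows what happens when nitrogen carries that ring, which keeps the expected range wide. No shift beyond the scatter is expected in this assay, and the expected step of a 1.1-fold lower number from compound 2 to compound 3 (0.03 log units; within the scatter) has no firm direction. The estimate for compound 3 is 260 nM, with an expected range from 110 nM to 620 nM in repeat measurements.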

Compound 3, half-maximal inhibitory concentration: 260 nM
Estimate against measurement, compound 3: no gap at the digits printed; low and high end bracket the measured number.
By their numbers in this assay, from the lowest: compounds 3, 1 and 2 (each within the scatter of the next).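

Anilino in place of propylsulfanyl on a saturated chain carbon bound to a saturated ring carbon gives a 1.1-fold lower number from compound 2 to compound 3 (0.03 log units; within the scatter) in this assay, so this larger group with an aromatic ring reads alike with the propyl chain on sulfur at this place. The tighter comparison is anilino in place of phenylsulfanyl, a 1.0-fold lower number from compound 1 to compound 3 (0.02 log units; within the scatter), where the aromatic ring stays and nitrogen takes the place of sulfur, a swap that the earlier pair did not test and that also leaves the number within the scatter. Nothing available gives a reason why these three compounds read alike.

The compounds shown leave open whether this place would read the same with phenoxy, a carboxylic acid, a primary amine or a longer chain on the saturated chain carbon. From the compounds shown here alone, all three also share one core, so the effect of a change elsewhere on it in this assay remains open as well.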